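Swapping the aryl group on the triazole nitrogen

The source may report more compounds than this note shows. Statements on the series, on what has been measured and on what is new or still open speak of the compounds shown alone.

Measured so far:
Compound 1, `CCc1ccccc1-n1nncc1CN1C(=O)C2(C(C#N)=C(N)Oc3c(N)cc4nc5ccccc5nc4c32)c2ccccc21`: in a functional assay on HCT-116 cells (Homo sapiens) for antiproliferative activity, read by MTT assay, with a stated time of 48 h (on this read-out lower numbers stand for stronger inhibition and higher numbers for weaker inhibition), compound 1 gives 10300 nM.
Compound 2, `COc1ccc(-n2nncc2CN2C(=O)C3(C(C#N)=C(N)Oc4c(N)cc5nc6ccccc6nc5c43)c3ccccc32)cc1`: in this assay compound 2 gives only a limit of the assay, > 50000 nM.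

Compound 2 thus stands at the weak end of what has been measured, and its true number is not known. Among the measured compounds shown here, the single measured step, an at least 4.8-fold higher number from compound 1 to compound 2 (0.68 log units; beyond the scatter), shows that replacing 2-ethylphenyl with 4-methoxyphenyl on the aromatic nitrogen weakened inhibition; because of the limit of > 50000 nM in this assay, at which 1 of the 2 values shown sits, the size of that loss is only bounded from below. Compound 3, `Cc1ccc(C)c(-n2nncc2CN2C(=O)C3(C(C#N)=C(N)Oc4c(N)cc5nc6ccccc6nc5c43)c3ccccc32)c1`, carries the change (2,5-dimethylphenyl in place of 4-methoxyphenyl on an aromatic nitrogen). It therefore returns to a phenyl bearing methyl groups rather than a methoxy group, in that respect closer to compound 1 than to compound 2, so a step back toward stronger inhibition in this assay is expected, though of uncertain size. Compound 3 is estimated at 15000 nM, with a range from 5000 nM to 50000 nM. This corresponds to an expected at least 3.3-fold lower number from compound 2 to compound 3 (0.52 log units; beyond the scatter).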

Compound 3, half-maximal inhibitory concentration: > 50000 nM
Compound 3: a limit, no number (the forecaster's own chance of this, stated with the estimate: 25%); at least 3.3-fold (0.52 log units) between middle value and limit.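

Compound 3 gives > 50000 nM in this assay, which is again a limit of the assay and not a number. Replacing 4-methoxyphenyl with a group of carbon only and no hydrogen-bond acceptor therefore does not bring a measurable value back, and exchanging 2-ethylphenyl for 2,5-dimethylphenyl gives an at least 4.8-fold higher number from compound 1 to compound 3 (0.68 log units; beyond the scatter), so a phenyl carrying small carbon groups is not enough by itself. The step between compound 2 and compound 3 cannot be read, and neither can be placed ahead of the other: the limit of > 50000 nM in this assay, at which 2 of the 3 values shown sit.

Going by these compounds, with compound 1 the only one of the three to give a number, what sets 2-ethylphenyl apart from 2,5-dimethylphenyl stays open. Also open, on these data alone, is whether a plain phenyl, or a phenyl carrying a propyl chain or an amine, would give a number in this assay.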